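From 3-Chloropropyl to 1-Hydroxycyclohexyl

A few compounds are considered here, and "the series" means these few. Any claim that something is new, unique, unknown or untested is made for them only; others in the source may bear on it.

Within the data shown here, in a functional assay on HeLa cells (Homo sapiens) for antiproliferative activity, read by sulforhodamine B assay, with a stated time of 48 h (a lower number here means a stronger inhibitor of growth, a higher number a weaker inhibitor of growth), compound 3 (`O=C1COc2ccccc2N1CCCn1cc(CCCCl)nn1`) has the lowest number of the three compounds measured so far, at 100 nM against compound 2 (`CCCCc1cn(CCCN2C(=O)COc3ccccc32)nn1`) at 1020 nM and compound 1 (`Cc1ccc(-c2cn(CCCN3C(=O)COc4ccccc43)nn2)cc1`) at 14300 nM on the same core. Compound 4 (`O=C1COc2ccccc2N1CCCn1cc(C2(O)CCCCC2)nn1`) keeps that core but carries 1-hydroxycyclohexyl in place of 3-chloropropyl on an aromatic carbon.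

Among the measured compounds shown here, three measured steps bear on this change, and all are large. Butyl in place of 4-methylphenyl gave a 14-fold lower number from compound 1 to compound 2 (1.15 log units; beyond the scatter) and 3-chloropropyl in place of 4-methylphenyl gave a 140-fold lower number from compound 1 to compound 3 (2.16 log units; beyond the scatter) at this same carbon. Chloro in place of methyl on the chain gave a 10-fold lower number from compound 2 to compound 3 (1.01 log units; beyond the scatter) as well. The number has therefore moved strongly with the group at this carbon, although three compounds show little more than that. For the measured compounds named here, no measured compound carries a hydroxyl group or a non-aromatic ring, so the size of the step remains uncertain. Compound 4 also has no chlorine, and compound 2, likewise without one, stands at 1020 nM in this assay as the nearest guide. A large step towards a higher number is therefore expected, with the estimate being a 10-fold higher number from compound 3 to compound 4 (1.00 log units; beyond the scatter) in this assay for this change. Compound 4 is expected at 1000 nM (from 250 nM to 5000 nM as the estimated range).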

Compound 4, concentration for 50% growth inhibition: 2000 nM
For compound 4 the middle estimate is 2.0-fold (0.30 log units) below the measured one; measured number inside the range.
By their numbers in this assay, from the lowest: compound 3; then compounds 2 and 4 (each within the scatter of the next); then compound 1.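

In this assay, the 1-hydroxycyclohexyl group on this aromatic carbon does not keep the low number of compound 3 (100 nM), and the change costs a large step (a 20-fold higher number from compound 3 to compound 4 (1.30 log units; beyond the scatter)). A group with a ring and a hydroxyl, new at this position, lands level with the open butyl chain (a 2.0-fold higher number from compound 2 to compound 4 (0.29 log units; within the scatter)), so these two different groups cannot be told apart here, while it still clearly improves on 4-methylphenyl (a 7.2-fold lower number from compound 1 to compound 4 (0.85 log units; beyond the scatter)). Of the four compounds, only compound 3 carries chlorine, and the other three all stand well above it, which makes 3-chloropropyl the one clear outlier at this carbon, although nothing shown here gives a reason for the size of that gap.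

The compounds shown cannot separate the effect of the hydroxyl from that of the ring, and a plain cyclohexyl group on the same carbon would pull those two apart. From the compounds shown here alone, whether the chlorine itself matters or any three-carbon chain ending in a heteroatom would serve also stays open, and a 3-hydroxypropyl or 3-bromopropyl group would test that directly.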